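Replacing the Phenylethenyl Amide on the Shared Core

The compounds below may be only part of what the source reports. "The series", "measured", "known", "first", "only" and "open" are said of these compounds alone.

Compound 1 `O=C(Nc1cc(Sc2ncn[nH]2)c(O)c2ccccc12)c1cccc([N+](=O)[O-])c1` gives 26900 nM in a functional assay on PC-3 cells (Homo sapiens) for antiproliferative activity, read by MTT assay, with a stated time of 48 h; on this read-out lower numbers stand for stronger inhibition and higher numbers for weaker inhibition.
Compound 2 `O=C(Nc1cc(Sc2ncn[nH]2)c(O)c2ccccc12)c1cccc(Cl)c1` gives 85600 nM in this assay.
Compound 3 `O=C(/C=C/c1ccccc1)Nc1cc(Sc2ncn[nH]2)c(O)c2ccccc12` gives > 100000 nM in this assay.

Compound 3 stands only at a limit: its reading of > 100000 nM is a ceiling of this assay, not a number (the limit of > 100000 nM in this assay, at which 1 of the 3 values shown sits). Compound 4 `COc1ccc(C(=O)Nc2cc(Sc3ncn[nH]3)c(O)c3ccccc23)cc1` differs from compound 3 by 4-methoxyphenyl in place of 2-phenylethenyl on a carbonyl carbon. Among the compounds with values here, the steps that bear on this change are an at least 3.7-fold higher number from compound 1 to compound 3 (0.57 log units; beyond the scatter) and an at least 1.1-fold higher number from compound 2 to compound 3 (0.06 log units; that floor lies within the scatter), both running toward the limit as an aryl amide gives way to the phenylethenyl amide. Compound 4 runs the other way, back to an aryl amide, so a lower number is expected, near the span between compound 1 and compound 2. Compound 4 is estimated at 60000 nM (from 20000 nM to 150000 nM), which is an expected step of an at least 1.6-fold lower number from compound 3 to compound 4 (0.22 log units; that floor lies within the scatter).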

Compound 4, half-maximal inhibitory concentration: > 100000 nM
Compound 4: a limit, no number; the forecaster's own chance of this, stated with the estimate: 35%; middle value at least 1.6-fold (0.22 log units) away from the limit.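

Compound 4 also stands at a limit in this assay, so a return to an aryl amide on this carbonyl carbon does not by itself restore a readable number, and the phenylethenyl amide of compound 3 is not alone at that limit: the limit of > 100000 nM in this assay, at which 2 of the 4 values shown sit. Placing 4-methoxyphenyl on this carbonyl carbon gives an at least 3.7-fold higher number from compound 1 to compound 4 (0.57 log units; beyond the scatter), while the same group gives an at least 1.1-fold higher number from compound 2 to compound 4 (0.06 log units; that floor lies within the scatter). The step from the limit of compound 3 to the limit of compound 4 cannot be read.

From the compounds shown here alone, it remains open whether an amine or a carboxylic acid on this aryl ring, or a longer chain in its place, would bring a number back within range.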